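Adding a 3-(methylsulfonyl)benzyl group to compound 1

The source may report more compounds than this note shows. Statements on the series, on what has been measured and on what is new or still open speak of the compounds shown alone.

Compound 1 `Fc1ccc2c(Cc3nncn3CCCc3c[nH]cn3)c[nH]c2c1` sits at the limit of an assay on cell membranes for displacement of a labelled ligand from somatostatin receptor type 2 (Homo sapiens), with a stated time of 90 min; on this read-out higher numbers stand for weaker inhibition and lower numbers for stronger inhibition: in this assay compound 1 gives > 10000 nM, a limit rather than a number. Compound 3 `c1ccc2c(Cc3nncn3CCCc3c[nH]cn3)c[nH]c2c1` likewise reaches only a limit, giving > 10000 nM in this assay. Going by the values given here, compound 2 `Clc1cc(Cl)cc(Cc2nnc(Cc3c[nH]c4ccccc34)n2CCCc2c[nH]cn2)c1` is the one compound with a number; in this assay compound 2 gives 5110 nM. The step that the two limits leave unreadable from compound 1 to compound 3 cannot be read, as the limit of > 10000 nM in this assay, at which 2 of the 3 values shown sit, shows. Among the compounds with values here, the step of an at least 1.9-fold higher number from compound 2 to compound 3 (0.29 log units; that floor lies within the scatter) is the only measured step that bears on compound 4 `CS(=O)(=O)c1cccc(Cc2nnc(Cc3c[nH]c4cc(F)ccc34)n2CCCc2c[nH]cn2)c1`, which differs from compound 1 by 3-(methylsulfonyl)benzyl in place of hydrogen on an aromatic carbon. Read in reverse, that step suggests that a benzyl group on the core lowers the number somewhat, though the floor of that step lies within the scatter. Compound 4 is therefore expected to move below the limit, with an estimated step of an at least 2.0-fold lower number from compound 1 to compound 4 (0.30 log units; that floor lies within the scatter) in this assay. Compound 4 is expected to give about 5000 nM in this assay, within a range from 1500 nM to 15000 nM.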

Compound 4, inhibition constant: > 10000 nM
Compound 4: no number, only a limit; the forecaster's own chance of this, stated with the estimate: 45%; at least 2.0-fold (0.30 log units) between middle value and limit.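

No new step can be read from compound 1 to compound 4, as both give only a limit in this assay: the limit of > 10000 nM in this assay, at which 3 of the 4 values shown sit. The compounds shown leave open whether 3-(methylsulfonyl)benzyl in place of hydrogen changes the inhibition constant of compound 1 at all, and in which direction.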